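The source may hold more compounds than are shown below. What is called first, only, known or untested is meant among the compounds shown, and "the series" means these compounds.

Four compounds share a core built from the same rings, and they are compared in a functional assay on SGC-7901 cells (Homo sapiens) for antiproliferative activity, read by MTT assay, with a stated time of 72 h; a higher number here means a weaker inhibitor, a lower number a stronger inhibitor. Compound 1 `CCOC(=O)c1cc(-c2cc(OC)c(OC)c(OC)c2)c(-c2ccc(OC)c([N+](=O)[O-])c2)s1` carries an ethyl group on the oxygen of its ester and a nitro group on one aromatic ring. In this assay compound 1 gives 18100 nM. Compound 2 `CCOC(=O)c1cc(-c2cc(OC)c(OC)c(OC)c2)c(-c2ccc(OC)c(OCc3ccccc3)c2)s1` differs from compound 1 by benzyloxy in place of nitro on an aromatic carbon. For compound 2 this assay reports only a limit, > 100000 nM. That change gave an at least 5.5-fold higher number from compound 1 to compound 2 (0.74 log units; beyond the scatter), a step shaped by the limit of > 100000 nM in this assay, at which 1 of the 3 values shown sits.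

Compound 3 `COc1ccc(-c2sc(C(=O)O)cc2-c2cc(OC)c(OC)c(OC)c2)cc1[N+](=O)[O-]` differs from compound 1 by hydrogen in place of ethyl on an oxygen next to a carbonyl group. In this assay compound 3 gives 23300 nM, and the step of a 1.3-fold higher number from compound 1 to compound 3 (0.11 log units; within the scatter) shows that the ester and the acid behave alike here.

Compound 4 `COc1ccc(-c2sc(C(=O)O)cc2-c2cc(OC)c(OC)c(OC)c2)cc1OCc1ccccc1` has not yet been measured. It differs from compound 3 by benzyloxy in place of nitro on an aromatic carbon. This is the same change that separates compound 2 from compound 1: the group that leaves, the group that enters and the place around it read the same word for word. The cores differ only in the way described for compound 3 against compound 1.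

The expected step from compound 3 to compound 4 is therefore a 6.4-fold higher number from compound 3 to compound 4 (0.81 log units; beyond the scatter), resting on the step from compound 1 to compound 2, an at least 5.5-fold higher number from compound 1 to compound 2 (0.74 log units; beyond the scatter), and on the value of compound 3, 23300 nM. Compound 4 is estimated at 150000 nM, with a range from 60000 nM to 400000 nM, and the assay may well report only a limit for it.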

Compound 4, half-maximal inhibitory concentration: > 100000 nM
Compound 4: no number, only a limit; the forecaster's own chance of this, stated with the estimate: 75%; the middle value does not contradict the limit.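

In this assay compound 4 is reported only as a limit, > 100000 nM, and not as a number. On the acid core, benzyloxy in place of nitro on an aromatic carbon gave an at least 4.2-fold higher number from compound 3 to compound 4 (0.63 log units; beyond the scatter), so the change weakens the compound on the acid core as well as on the ester core, and the two steps can be set side by side: the same change on two cores in this assay, an at least 5.5-fold higher number (0.74 log units; beyond the scatter) from compound 1 to compound 2 and an at least 4.2-fold higher number (0.63 log units; beyond the scatter) from compound 3 to compound 4; the limit leaves it open whether they differ. This shows that the direction of the change carries over from one core to the other, but it does not show that the size carries over, and the step from the ester compound 2 to the acid compound 4 cannot be read, as both ends are limits: the limit of > 100000 nM in this assay, at which 2 of the 4 values shown sit.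

The compounds shown leave open how the series responds to other groups on this aromatic carbon, such as an amine or a hydroxyl group, and whether any of them would give a stronger compound than the nitro compounds. They also leave open whether the ester and the acid differ at all once benzyloxy is present, and whether an amide in their place would behave like either of them.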